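Acid to Ethyl Ester on a Second Chloroacetamide Core

The source may report more compounds than this note shows. Statements on the series, on what has been measured and on what is new or still open speak of the compounds shown alone.

Measured compounds:
compound 1, `O=C(O)c1cc(-c2ccc(Oc3ccccc3)cc2)nn1C1CCCN(C(=O)CCl)C1`, 400 nM
compound 2, `O=C(CCl)Nc1ccc(Cn2nc(-c3ccc(Oc4ccccc4)cc3)cc2C(=O)O)cc1`, 1200 nM
compound 3, `CCOC(=O)c1cc(-c2ccc(Oc3ccccc3)cc2)nn1C1CCCN(C(=O)CCl)C1`, 1200 nM

In a functional assay on Maver1 cells (Homo sapiens) for inhibition, read by luminescence and CellTiter-Glo, with a stated time of 72 h (on this read-out higher numbers stand for weaker inhibition and lower numbers for stronger inhibition), compound 1 gives 400 nM. Compound 3 differs from compound 1 by ethyl in place of hydrogen on an oxygen next to a carbonyl group and in this assay compound 3 gives 1200 nM, which is a 3.0-fold higher number from compound 1 to compound 3 (0.48 log units; beyond the scatter). Compound 2 rests on a different core; the difference between the two cores is not broken down here. In this assay compound 2 gives 1200 nM, level with compound 3 within the usual scatter.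

Compound 4, `CCOC(=O)c1cc(-c2ccc(Oc3ccccc3)cc2)nn1Cc1ccc(NC(=O)CCl)cc1`, is not yet measured and differs from compound 2 by ethyl in place of hydrogen on an oxygen next to a carbonyl group, the same change seen from compound 1 to compound 3. The step from compound 2 to compound 4 is expected to be a 3.0-fold higher number from compound 2 to compound 4 (0.48 log units; beyond the scatter), because compound 1 to compound 3 showed a 3.0-fold higher number from compound 1 to compound 3 (0.48 log units; beyond the scatter). Compound 4 is therefore expected to give 3600 nM, plausibly between 1500 nM and 9000 nM.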

Compound 4, half-maximal inhibitory concentration: 400 nM
Compound 4: middle estimate off by 9.0-fold (0.95 log units), on the high side; measured number below the stated range.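

In this assay, ethyl in place of hydrogen on the oxygen next to the carbonyl group of the core of compound 2 gives a 3.0-fold lower number from compound 2 to compound 4 (0.48 log units; beyond the scatter). The change therefore does not carry over from one core to the other, and its direction reverses: the same change on two cores in this assay, a 3.0-fold higher number (0.48 log units; beyond the scatter) from compound 1 to compound 3 and a 3.0-fold lower number (0.48 log units; beyond the scatter) from compound 2 to compound 4, 9.0-fold (0.95 log units) apart, beyond the scatter of two such steps. This shows that the step on one core did not predict the step on the other, but with one pair per core it does not show what in the cores sets them apart, or how any other change would carry over.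

The compounds shown leave open whether a methyl ester or a primary amide in place of the carboxy group would split the two cores in the same way. They also leave open whether the reversal would persist with an acrylamide in place of the chloroacetamide.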